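A few compounds are considered here, and "the series" means these few. Any claim that something is new, unique, unknown or untested is made for them only; others in the source may bear on it.

Measured so far in a functional assay on the whole organism (strain Sprague-Dawley CD) for inhibition, with Rattus norvegicus as the target, read by paw edema, at a dose of 30 mg/kg by the intraperitoneal route; a higher number here means a stronger effect of the compound at the dose given, a lower number a weaker effect:
compound 1 `CCOC(=O)C(=O)Nc1cccccc1=O` gives 84%
compound 2 `CCOC(=O)C(=O)Nc1c(Oc2ccccc2)ccccc1=O` gives 0%

Going by the values given here, compound 2 stands lowest of the two values, and the only step known here is a number 84 percentage points lower from compound 1 to compound 2 (beyond the scatter). The step now followed leads to compound 3 `CCOC(=O)C(=O)Nc1c(C)ccccc1=O`, with methyl in place of phenoxy on an aromatic carbon. Among the compounds with values here, the single measured step, phenoxy in place of hydrogen, was large and bears on this change, but the group that enters is neither hydrogen nor phenoxy, so the data give no direct guide. An upward step is expected, partway back toward compound 1: a number 45 percentage points higher from compound 2 to compound 3 (beyond the scatter). Compound 3 is thus estimated at 45%, within 5% to 85%.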

Compound 3, a percentage reported as inhibition, in the whole organism at one dose (the size of the read-out at that dose, not a potency): 47%
For compound 3 the middle estimate is 2 percentage points below the measured one, and the stated range covers the measured number.
By their numbers in this assay, from the lowest: compound 2; then compound 3; then compound 1.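

In this assay a group at this place need not abolish the effect: methyl in place of phenoxy brings a number 47 percentage points higher from compound 2 to compound 3 (beyond the scatter) and so the complete loss belongs to phenoxy, not to every group here. Methyl still does not match hydrogen, with a number 37 percentage points lower from compound 1 to compound 3 (beyond the scatter) as the step, so even a single carbon at this place changes the outcome.

From the compounds shown here alone, whether an ethyl chain, a methoxy group or a chlorine atom here would land nearer compound 1 or compound 2 stays open. Nothing measured here gives a reason for either step.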